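Dropping both chlorines from the pyrazole-bound phenyl

This account rests on a few compounds, and the source may have more. Where it says the series, first, only, none or still open, it means among the compounds named here.

Measured so far:
- compound 1 `O=C1COc2ccc(-c3nn(-c4ccc(Br)cc4)cc3-c3ccccc3)cc2N1`: 91.5%
- compound 2 `O=C1COc2ccc(-c3nn(-c4ccc(Cl)cc4)cc3-c3ccccc3)cc2N1`: 91.9%
- compound 3 `O=C1COc2ccc(-c3nn(-c4cc(Cl)cc(Cl)c4)cc3-c3ccccc3)cc2N1`: 50.5%

In a functional assay on MV4-11 cells (Homo sapiens) for cytotoxicity, read by colorimetric assay and MTT assay, with a stated time of 3 days, tested at 20 uM (on this read-out higher numbers stand for a weaker effect at the one concentration tested and lower numbers for a stronger effect), compound 3 stands lowest of the three, which here means the strongest effect. Compound 4 `O=C1COc2ccc(-c3nn(-c4ccccc4)cc3-c3ccccc3)cc2N1` is not yet measured; it differs from compound 3 thus: phenyl in place of 3,5-dichlorophenyl on an aromatic nitrogen. Within the data shown here, the steps that bear on this are a number 41 percentage points lower from compound 1 to compound 3 (beyond the scatter) and a number 41.4 percentage points lower from compound 2 to compound 3 (beyond the scatter), both large, whereas a number 0.4 percentage points higher from compound 1 to compound 2 (within the scatter) stayed within the scatter. Both chloro-bearing substituents on that aromatic nitrogen came with weak effects, and the 3,5-dichlorophenyl alone gave the strong one; removing it is therefore expected to move the number back up, about a number 34.5 percentage points higher from compound 3 to compound 4 (beyond the scatter). Compound 4 is estimated at 85%, within 62% to 100%.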

Compound 4, a percentage reported as activity, at one concentration (the size of the read-out at that concentration, not a potency): 97.9%
Compound 4: the middle estimate sits 12.9 percentage points below what was measured; the measured number falls inside the stated range.
By their numbers in this assay, from the lowest: compound 3; then compounds 1, 2 and 4 (each within the scatter of the next).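

In this assay, replacing the 3,5-dichlorophenyl with plain phenyl gives a number 47.4 percentage points higher from compound 3 to compound 4 (beyond the scatter), so the stronger effect does not survive losing both chlorines. The plain phenyl also matches the 4-chlorophenyl and 4-bromophenyl, with a number 6 percentage points higher from compound 2 to compound 4 (within the scatter) and a number 6.4 percentage points higher from compound 1 to compound 4 (within the scatter), which leaves the 3,5-dichlorophenyl alone in standing apart among these four compounds. No available evidence explains this difference. On these data alone, it remains open whether both chlorines are needed, and whether a methoxy group or an amine on that phenyl would give a similar effect.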